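From acetyl to pyridin-2-yl on a ring nitrogen

The source may report more compounds than this note shows. Statements on the series, on what has been measured and on what is new or still open speak of the compounds shown alone.

For the measured compounds named here, in a functional assay on PC-3 cells (Homo sapiens) for inhibition, read by MTT assay, with a stated time of 48 h (a lower number here means a stronger inhibitor, a higher number a weaker inhibitor), compound 1 `CCN1CCN(C(=S)SCCCOc2ccc3c(=O)c(-c4ccc(OC)cc4)coc3c2)CC1` gives 7080 nM and compound 2 `COc1ccc(-c2coc3cc(OCCCSC(=S)N4CCN(C(C)=O)CC4)ccc3c2=O)cc1` gives 4310 nM, so compound 2 stands level with the only other measured compound. Compound 3 `COc1ccc(-c2coc3cc(OCCCSC(=S)N4CCN(c5ccccn5)CC4)ccc3c2=O)cc1` carries pyridin-2-yl in place of acetyl on an amine nitrogen in a ring. Going by the values given here, the one measured step at this place, a 1.6-fold lower number from compound 1 to compound 2 (0.22 log units; within the scatter), put acetyl in place of ethyl, and no measured step brings a ring here, so it is only a weak guide. On that evidence, the expected change is a 1.1-fold lower number from compound 2 to compound 3 (0.03 log units; within the scatter), with no shift beyond the scatter anticipated. Compound 3 is estimated at 4000 nM, within an expected range of 1300 nM to 12000 nM.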

Compound 3, half-maximal inhibitory concentration: 17400 nM
The estimate for compound 3 lay 4.4-fold (0.64 log units) below the measured number; measured number outside the range, above it.
By their numbers in this assay, from the lowest: compounds 2 and 1 (each within the scatter of the next); then compound 3.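

In this assay, this amine nitrogen in a ring now shows that its substituent can matter: pyridin-2-yl gives a 4.0-fold higher number from compound 2 to compound 3 (0.61 log units; beyond the scatter) and a 2.5-fold higher number from compound 1 to compound 3 (0.39 log units; beyond the scatter). Both steps lie beyond the scatter, so compound 3 is a weaker inhibitor than compound 1 and compound 2, whose acetyl and ethyl groups remained within the scatter of each other. No measurement shown here explains this weakening.

From the compounds shown here alone, it remains open whether the change follows from any six-membered aromatic ring or from the nitrogen in pyridin-2-yl. Phenyl, with carbon in place of that nitrogen, would separate the two, while cyclohexyl would test a ring that is not aromatic.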